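Amide aryl swap to cyclohexenyl: compound 2 to compound 3

The compounds below may be only part of what the source reports. "The series", "measured", "known", "first", "only" and "open" are said of these compounds alone.

Measured so far in an assay on HEK293 cells for displacement of a labelled ligand from metabotropic glutamate receptor 5 (Rattus norvegicus); on this read-out lower numbers stand for stronger inhibition and higher numbers for weaker inhibition:
compound 1 `O=C(Nc1cc(-c2ccccc2)nn1-c1ccccc1)c1cccc(C(F)(F)F)c1`, 1650 nM
compound 2 `Cc1ccc(C(=O)Nc2cc(-c3ccccc3)nn2-c2ccccc2)cn1`, 3480 nM

For the measured compounds named here, compound 2 holds the highest of the two numbers; the single measured step, a 2.1-fold higher number from compound 1 to compound 2 (0.32 log units; beyond the scatter), separates it from its only neighbour and was modest. Compound 3 `O=C(Nc1cc(-c2ccccc2)nn1-c1ccccc1)C1=CCCCC1` differs from compound 2 by cyclohex-1-en-1-yl in place of 6-methylpyridin-3-yl on a carbonyl carbon. Going by the values given here, no measured step places a non-aromatic ring on this carbonyl carbon, so the one step available offers only a rough guide to the size of change. A modest step is expected in this assay, direction uncertain, with a 1.3-fold higher number from compound 2 to compound 3 (0.11 log units; within the scatter) as the working estimate. Compound 3 is estimated at 4500 nM (range 1500 nM to 14000 nM).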

Compound 3, inhibition constant: 4470 nM
Estimate against measurement, compound 3: 1.0-fold (0.00 log units) above; measured number inside the range.
By their numbers in this assay, from the lowest: compound 1; then compounds 2 and 3 (each within the scatter of the next).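

In this assay, a non-aromatic carbocycle on this carbonyl carbon is tolerated at the level of the 6-methylpyridin-3-yl group: cyclohex-1-en-1-yl in its place gives a 1.3-fold higher number from compound 2 to compound 3 (0.11 log units; within the scatter). Set against 3-(trifluoromethyl)phenyl, the same ring gives a 2.7-fold higher number from compound 1 to compound 3 (0.43 log units; beyond the scatter), so neither replacement reaches the number of compound 1. No available evidence bears on the reason for these results.

Open, from the compounds shown here alone, is whether a fully saturated cyclohexyl ring, a smaller cyclopentenyl ring or an open pentyl chain on this carbonyl carbon stays at this level. Also open, going by these compounds, is whether a trifluoromethyl group on the cyclohexene ring would shift the number.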